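The source may hold more compounds than are shown below. What is called first, only, known or untested is meant among the compounds shown, and "the series" means these compounds.

Working notes on the series. Of the compounds shown here, two have been measured in a functional assay on MOLT-4 cells (Homo sapiens) for inhibition, read by sulforhodamine B assay, with a stated time of 48 h; on this read-out lower numbers stand for stronger inhibition of growth and higher numbers for weaker inhibition of growth. Compound 1 `COc1cc(-c2cc(/C=C/C(=O)c3ccc(N)cc3)[nH]n2)cc(OC)c1OC` gives 1910 nM in this assay. Compound 2 `COc1ccc(-c2cc(/C=C/C(=O)c3ccc(OC)c(OC)c3)[nH]n2)cc1` gives 2670 nM in this assay. Compound 1 carries the smaller of the two numbers, but the gap to compound 2 lies within the usual scatter of repeated measurements, so the two cannot be separated on the data shown.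

Compound 3 `COc1cc(-c2cc(/C=C/C(=O)c3ccc(Cl)c(Cl)c3)[nH]n2)cc(OC)c1OC` is not yet measured. Against compound 1 it shows one change: 3,4-dichlorophenyl in place of 4-aminophenyl on a carbonyl carbon. For the measured compounds named here, no measured pair reports a step of this kind, so no direction can be read from the data. The pair of compound 1 and compound 2 differs at more than one place and offers no guidance on a single change at the carbonyl carbon.

Given that, the step from compound 1 to compound 3 is expected to be small, with no direction beyond the scatter, and is estimated at a 1.3-fold higher number from compound 1 to compound 3 (0.12 log units; within the scatter). For compound 3 in this assay the expected value is 2500 nM, with a range from 700 nM to 9000 nM.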

Compound 3, concentration for 50% growth inhibition: 4380 nM
Compound 3: the middle estimate sits 1.8-fold (0.24 log units) below what was measured; low and high end bracket the measured number.
By their numbers in this assay, from the lowest: compounds 1, 2 and 3 (each within the scatter of the next, the first and the last beyond it).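

For the compounds shown here, the first single-place step falls on the carbonyl carbon: 3,4-dichlorophenyl in place of 4-aminophenyl gives a 2.3-fold higher number from compound 1 to compound 3 (0.36 log units; beyond the scatter) in this assay, a modest shift toward weaker inhibition of growth. This shows that the group on the carbonyl carbon can move the read-out beyond the scatter, which the earlier pair, differing at more than one place, could not show. The change replaces a group counted with 1 hydrogen-bond donor and 1 hydrogen-bond acceptor by one counted with none, and nitrogen gives way to chlorine, but no measurement at hand explains the step.

On these data alone, whether a plain phenyl, 4-chlorophenyl or 4-hydroxyphenyl on the carbonyl carbon would sit nearer compound 1 or compound 3 remains open, so the step cannot yet be assigned to the loss of the amino group or to the arrival of the two chlorines. Also open, as far as these compounds go, is whether the same change gives a step of similar size on a core other than that of compound 1.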